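Removing the chloro group from compound 1

The compounds below may be only part of what the source reports. "The series", "measured", "known", "first", "only" and "open" are said of these compounds alone.

Measured compounds:
compound 1 `COc1ccc(-c2nc(C)c(C(=O)CSc3nc(-c4ccc(Cl)cc4)c(C#N)c(=O)[nH]3)s2)cc1`: 48%
compound 2 `Cc1nc(-c2ccccc2)sc1C(=O)CSc1nc(-c2ccc(Cl)cc2)c(C#N)c(=O)[nH]1`: 63.4%
compound 3 `Cc1nc(-c2ccc(Cl)cc2)sc1C(=O)CSc1nc(-c2ccc(Cl)cc2)c(C#N)c(=O)[nH]1`: 60%

In a functional assay on U-87MG ATCC cells for antiproliferative activity against U-87 MG (Homo sapiens), read by MTT assay, with a stated time of 48 h, tested at 50 uM (on this read-out lower numbers stand for a stronger effect and higher numbers for a weaker effect at the one concentration tested), compound 1 gives 48%, the lowest of the three numbers and the strongest effect here. Compound 3 comes nearest (a number 12 percentage points higher from compound 1 to compound 3 (beyond the scatter)) and compound 2 lies furthest (a number 15.4 percentage points higher from compound 1 to compound 2 (beyond the scatter)), both steps beyond the scatter. Compound 4 `COc1ccc(-c2nc(C)c(C(=O)CSc3nc(-c4ccccc4)c(C#N)c(=O)[nH]3)s2)cc1` differs from compound 1 in one place: hydrogen in place of chloro on an aromatic carbon. Among the measured compounds shown here, the only measured step of this kind runs the other way and sits on the other aromatic ring: a number 3.4 percentage points lower from compound 2 to compound 3 (within the scatter), within the scatter. On that basis no step beyond the scatter is expected from compound 1 to compound 4. Compound 4 is therefore estimated at 51%, with a range from 36% to 68%, which means a number 3 percentage points higher from compound 1 to compound 4 (within the scatter).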

Compound 4, a percentage reported as activity, at one concentration (the size of the read-out at that concentration, not a potency): 72.5%
For compound 4 the middle estimate is 21.5 percentage points below the measured one; measured number outside the range, above it.
By their numbers in this assay, from the lowest: compound 1; then compounds 3, 2 and 4 (each within the scatter of the next, the first and the last beyond it).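

Going from 4-chlorophenyl to phenyl at this position gives a number 24.5 percentage points higher from compound 1 to compound 4 (beyond the scatter) in this assay, the first sign that this chloro group matters for the effect on this core. Among the compounds shown here, the earlier compounds could not show this, since their only chloro-for-hydrogen step, on the other aromatic ring, stayed within the scatter. The size of this change therefore does not carry over from one core to the other: the same change on two cores in this assay, a number 3.4 percentage points lower (within the scatter) from compound 2 to compound 3 and a number 24.5 percentage points lower (beyond the scatter) from compound 4 to compound 1, 21.1 percentage points apart, beyond the scatter of two such steps

On these data alone, what bromo, a methyl group or an amine would do at this place remains open. So does whether the gap seen at the one concentration tested would hold as a difference in potency.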